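Adding fluoro to the chloro analogue in the cytotoxicity assay

The compounds below may be only part of what the source reports. "The series", "measured", "known", "first", "only" and "open" are said of these compounds alone.

For the measured compounds named here, compound 3 `N#Cc1ccc2c(Oc3ccccc3OCCn3ccc(=O)[nH]c3=O)cc(Cl)cc2c1` gives 24000 nM in an ADME assay on MT2 cells (Homo sapiens) for cytotoxicity, read by MTT assay (a higher number here means that more compound is tolerated, a lower number that less compound is tolerated), the only number in the set. Compound 1 `N#Cc1ccc2c(Oc3ccccc3OCCn3ccc(=O)[nH]c3=O)cc(F)cc2c1` reaches only a limit, > 100000 nM. Compound 2 `N#Cc1ccc2c(Oc3ccc(F)cc3OCCn3ccc(=O)[nH]c3=O)cccc2c1` likewise reaches only a limit, > 100000 nM. Both sit at the limit of > 100000 nM in this assay, at which 2 of the 3 values shown sit. Going by the values given here, the single measured step, an at least 4.1-fold lower number from compound 1 to compound 3 (0.61 log units; beyond the scatter), concerns the halogen on the shared core. Compound 4 `N#Cc1ccc2c(Oc3ccc(F)cc3OCCn3ccc(=O)[nH]c3=O)cc(Cl)cc2c1` differs from compound 3 by fluoro in place of hydrogen on an aromatic carbon. Among the compounds with values here, no measured step covers this change directly, and compound 2, which carries the same fluoro on its outer ring, stands only at a limit, so the direction is unclear. For compound 4 the change is expected to bring a 1.3-fold higher number from compound 3 to compound 4 (0.10 log units; within the scatter), within the scatter. Compound 4 is estimated at 30000 nM, range 10000 nM to 100000 nM.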

Compound 4, half-maximal cytotoxic concentration: 16000 nM
Compound 4: middle estimate off by 1.9-fold (0.27 log units), on the high side; the measured number falls inside the stated range.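

In this assay, fluoro in place of hydrogen at this position, meta to a large group and para to a large group, gives a 1.5-fold lower number from compound 3 to compound 4 (0.18 log units; within the scatter), so with chloro on the shared core the change has no effect that can be told from scatter. With the fluoro kept, chloro in place of hydrogen gives an at least 6.2-fold lower number from compound 2 to compound 4 (0.79 log units; beyond the scatter), a second case in which a chloro compound has the lower number. Compound 2 gives only a limit, so that step has no exact size: the limit of > 100000 nM in this assay, at which 2 of the 4 values shown sit.

On these data alone, whether an amine or a methoxy group at the fluoro position would also leave the number unchanged remains open. So does whether bromo in place of chloro would lower it further.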